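Chain growth at the aromatic nitrogen: cytotoxicity notes

The source may hold more compounds than are shown below. What is called first, only, known or untested is meant among the compounds shown, and "the series" means these compounds.

Measured in a functional assay on HGC cells (Homo sapiens) for cytotoxicity, read by MTT assay, with a stated time of 48 h; on this read-out lower numbers stand for stronger inhibition and higher numbers for weaker inhibition:
compound 1, `CC(C)n1c(/C=C2/C(=O)Nc3ccc(Br)cc32)nc2ccccc21`: 12400 nM
compound 2, `CCn1c(/C=C2/C(=O)Nc3ccc(Br)cc32)nc2ccccc21`: > 50000 nM, a limit of the assay and not a number
compound 3, `Cn1c(/C=C2/C(=O)Nc3ccc(Cl)cc32)nc2ccccc21`: 43600 nM

Compound 3 gives the highest number among the two numbers read in this assay. The step methyl in place of hydrogen on a saturated chain carbon bound to an aromatic nitrogen and a saturated chain carbon gives an at least 4.0-fold lower number from compound 2 to compound 1 (0.60 log units; beyond the scatter). Compound 4, `CCn1c(/C=C2/C(=O)Nc3ccc(Cl)cc32)nc2ccccc21`, is not yet measured; it arises from compound 3 by methyl in place of hydrogen on a saturated chain carbon bound to an aromatic nitrogen. This is the same kind of change as the step from compound 2 to compound 1, not the same: there the saturated chain carbon is bound to an aromatic nitrogen and a saturated chain carbon, here only to an aromatic nitrogen. The difference between the two cores is not broken down here. Compound 4 is expected to move by a 1.2-fold lower number from compound 3 to compound 4 (0.10 log units; within the scatter), resting on compound 3 at 43600 nM and on the scatter of this assay. Compound 4 is estimated at 35000 nM, within 12000 nM to 100000 nM.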

Compound 4, half-maximal inhibitory concentration: > 50000 nM
Compound 4: only a limit was reported (the forecaster's own chance of this, stated with the estimate: 35%); at least 1.4-fold (0.15 log units) between middle value and limit.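

Compound 4 gives > 50000 nM in this assay, a limit of the assay and not a number. Methyl in place of hydrogen on a saturated chain carbon bound to an aromatic nitrogen gives an at least 1.1-fold higher number from compound 3 to compound 4 (0.05 log units; that floor lies within the scatter), so the gain seen on the bromo core does not carry over to this chloro pair: the same change on two cores in this assay, an at least 4.0-fold lower number (0.60 log units; beyond the scatter) from compound 2 to compound 1 and an at least 1.1-fold higher number (0.05 log units; that floor lies within the scatter) from compound 3 to compound 4, at least 4.6-fold (0.66 log units) apart, beyond the scatter of two such steps This does not fix the true size of the step on the chloro core, and the step from compound 2 to compound 4 cannot be read, as both compounds sit at the limit: the limit of > 50000 nM in this assay, at which 2 of the 4 values shown sit.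

Open, on these data alone, is whether the chain of compound 1 lowers the number with chloro in place of bromo. Also open, as far as these compounds go, is how a longer chain or an amine on that chain would read on either core.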